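Removing the Silicon-Containing Chain from Compound 2

A few compounds are considered here, and "the series" means these few. Any claim that something is new, unique, unknown or untested is made for them only; others in the source may bear on it.

Compound 1 `COCn1c(CC(COCc2ccccc2)COCc2ccccc2)c(C)c(=O)[nH]c1=O` shows in a functional assay on MCF7 cells (Homo sapiens) for antiproliferative activity, read by MTT assay, with a stated time of 72 h (a higher number here means a weaker inhibitor, a lower number a stronger inhibitor), a value of 72600 nM. In this assay compound 2 `Cc1c(CC(O)COCc2ccccc2)n(COCC[Si](C)(C)C)c(=O)[nH]c1=O` gives > 100000 nM, which is a limit of the assay rather than a number. Compound 2 therefore stands at the limit of > 100000 nM in this assay, at which 1 of the 2 values shown sits. Compound 3 `COCn1c(CC(O)COCc2ccccc2)c(C)c(=O)[nH]c1=O` differs from compound 2 by a hydrogen atom in place of a group of 5 heavy atoms (4 carbon, 1 silicon; no ring), on a saturated chain carbon bound to an oxygen on a saturated carbon. For the measured compounds named here, no step between measured compounds is available for this change, so in this assay no shift beyond the scatter is expected in either direction. Compound 3 is estimated at 100000 nM, with a range from 30000 nM to 300000 nM. The expected step is a number no higher from compound 2 to compound 3 (the limit leaves the size open).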

Compound 3, half-maximal inhibitory concentration: > 100000 nM
Compound 3 gave a limit, no number; the forecaster's own chance of this, stated with the estimate: 60%; the middle value sits exactly at the limit.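

With the group of 5 heavy atoms replaced by a hydrogen atom, compound 3 still gives only a limit in this assay, as compound 2 does, so the step between them cannot be read and this change brings no measurable number: the limit of > 100000 nM in this assay, at which 2 of the 3 values shown sit.

Hydroxy in place of (benzyloxy)methyl gives an at least 1.3-fold higher number from compound 1 to compound 3 (0.13 log units; that floor lies within the scatter), so that change does not separate the two compounds either.

As far as these compounds go, what an amine or a carboxylic acid in place of the hydroxy would give stays open, as does the true size of the step from compound 2 to compound 3.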